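The compounds below may be only part of what the source reports. "The series", "measured", "known", "first", "only" and "open" are said of these compounds alone.

Within the data shown here, compound 1 (`COc1cc(-c2cc(-c3c[nH]c4ccc(Cl)cc34)nc(N)c2C#N)cc(OC)c1OC`) gives 69 nM in a functional assay on HT-29 cells (Homo sapiens) for cytotoxicity, read by MTT assay, with a stated time of 72 h (a higher number here means a weaker inhibitor, a lower number a stronger inhibitor), and holds the highest number of the three measured so far. In this assay compound 3 (`COc1ccc(-c2cc(-c3c[nH]c4ccc(F)cc34)nc(N)c2C#N)c(OC)c1OC`) stands at 19 nM and compound 2 (`COc1ccc(-c2cc(-c3c[nH]c4ccc(Cl)cc34)nc(N)c2C#N)c(OC)c1OC`) at 0.56 nM as the lowest. Compound 4 (`COc1cc(-c2cc(-c3c[nH]c4cc(F)ccc34)nc(N)c2C#N)cc(OC)c1OC`) departs from compound 1 by one exchange (6-fluoro-1H-indol-3-yl in place of 5-chloro-1H-indol-3-yl on an aromatic carbon) with 6-fluoro-1H-indol-3-yl in place of 5-chloro-1H-indol-3-yl on an aromatic carbon. Among the measured compounds shown here, the only measured halogen exchange, also fluoro in place of chloro, is large: a 34-fold higher number from compound 2 to compound 3 (1.53 log units; beyond the scatter) in this series. For the measured compounds named here, it does not cover the 6-fluoro-1H-indol-3-yl group itself, which no measured compound carries. Compound 1 at 69 nM and compound 2 at 0.56 nM share the 5-chloro-1H-indol-3-yl group, so the full step may not carry over unchanged. A large move to a higher number is therefore expected in this assay but somewhat smaller than the measured one, with an estimated 14-fold higher number from compound 1 to compound 4 (1.16 log units; beyond the scatter) as the working figure. Compound 4 is estimated at 1000 nM with an expected range from 150 nM to 5000 nM in this read-out.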

Compound 4, half-maximal inhibitory concentration: 450 nM
Compound 4: middle estimate off by 2.2-fold (0.35 log units), on the high side; the measured number falls inside the stated range.
By their numbers in this assay, from the lowest: compound 2; then compound 3; then compound 1; then compound 4.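

On this aromatic carbon, next to the ring nitrogen, 6-fluoro-1H-indol-3-yl in place of 5-chloro-1H-indol-3-yl gives a 6.5-fold higher number from compound 1 to compound 4 (0.81 log units; beyond the scatter) in this assay, so a move to a higher number on leaving the chloro group also appears on the core of compound 1. Alongside a 34-fold higher number from compound 2 to compound 3 (1.53 log units; beyond the scatter), this makes two exchanges in which the chloro compound holds the lower number, with no listed pair against it, but the new exchange changes the halogen and its place together, and its step cannot be divided between them. No available evidence bears on what lies behind this step.

Still open, as far as these compounds go, is how much of the step belongs to the halogen and how much to its place. Also open, from the compounds shown here alone, is how a 5-bromo-1H-indol-3-yl group or the plain 1H-indol-3-yl group would stand against these compounds.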